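This account rests on a few compounds, and the source may have more. Where it says the series, first, only, none or still open, it means among the compounds named here.

Within the data shown here, compound 3 `NS(=O)(=O)c1ccc(Nc2nncc3ccccc23)cc1` gives 12 nM in a functional assay on HT-29 cells (Homo sapiens) for antiproliferative activity, read by sulforhodamine B assay, with a stated time of 72 h (a lower number here means a stronger inhibitor, a higher number a weaker inhibitor), and stands second highest of the three measured members, with compound 1 `Cc1cc(NS(=O)(=O)c2ccc(Nc3nncc4ccccc34)cc2)no1` at 23 nM nearest (within the scatter) and compound 2 `Cc1cc(C)nc(NS(=O)(=O)c2ccc(Nc3nncc4ccccc34)cc2)n1` at 3.3 nM furthest. Compound 4 `N#Cc1ccc(Nc2nncc3ccccc23)cc1` differs from compound 3 by cyano in place of sulfamoyl on an aromatic carbon. The measured steps all concern the sulfonamide nitrogen: a 7.0-fold lower number from compound 1 to compound 2 (0.84 log units; beyond the scatter), a 1.9-fold lower number from compound 1 to compound 3 (0.28 log units; within the scatter) and a 3.6-fold higher number from compound 2 to compound 3 (0.56 log units; beyond the scatter). Among the measured compounds shown here, none of them removes the sulfamoyl group itself, so no measured step bears directly on the change to compound 4. The expectation for compound 4 in this assay is therefore uncertain; a modest rise, a 3.3-fold higher number from compound 3 to compound 4 (0.52 log units; beyond the scatter), is expected. Compound 4 is estimated at 40 nM, between 8 nM and 200 nM.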

Compound 4, half-maximal inhibitory concentration: 1.2 nM
Estimate against measurement, compound 4: 33-fold (1.52 log units) above; measured number outside the range, below it.
By their numbers in this assay, from the lowest: compound 4; then compound 2; then compounds 3 and 1 (each within the scatter of the next).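

In this assay, the change gives a 10-fold lower number from compound 3 to compound 4 (1.00 log units; beyond the scatter), so the sulfamoyl group is not required at this place, para to a large group: cyano, with fewer heavy atoms and no hydrogen-bond donor, is tolerated there and gives the lower number. The earlier steps shown here varied only the sulfonamide nitrogen and could not show this. Nothing available accounts for the size of this step.

The compounds shown leave open whether a carboxylic acid, a trifluoromethyl group or plain hydrogen at this place would match cyano. They also leave open whether a group is needed there at all.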